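The compounds below may be only part of what the source reports. "The series", "measured", "known", "first", "only" and "open" are said of these compounds alone.

Of the compounds shown here, three sharing one core have been tested in a functional assay on Raji cells (Homo sapiens) for antiproliferative activity, read by CCK-8 assay, with a stated time of 72 h, tested at 40 uM; a higher number here means more inhibition at the concentration tested (going by the name of the read-out), a lower number less inhibition. Compound 1 `CCOC(=O)c1sc(-c2cccc(NC(=O)c3ccc(F)cc3)c2)nc1Nc1ccc(N2CCN(C)CC2)cc1` gives 16.8%. Compound 2 `CCOC(=O)c1sc(-c2cccc(NC(=O)c3ccccc3F)c2)nc1Nc1ccc(N2CCN(C)CC2)cc1` gives 89.8%. Compound 3 `CN1CCN(c2ccc(Nc3nc(-c4cccc(NC(=O)c5ccc(F)cc5)c4)sc3C(N)=O)cc2)CC1` gives 95.3%, which lies far above compound 1 and close to compound 2, the latter gap within the scatter. Compound 4 `CN1CCN(c2ccc(Nc3nc(-c4cccc(NC(=O)c5ccccc5F)c4)sc3C(N)=O)cc2)CC1` differs from compound 3 only in 2-fluorophenyl in place of 4-fluorophenyl on a carbonyl carbon. The same change was seen once before: a number 73 percentage points higher from compound 1 to compound 2 (beyond the scatter), a large rise. Here, however, compound 3 already sits near the top of what this assay can report, so the same move is expected to leave almost no room for a further rise, and the expected step from compound 3 to compound 4 is a number 0.3 percentage points lower from compound 3 to compound 4 (within the scatter). Compound 4 is therefore estimated at 95%, within a range from 85% to 100%.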

Compound 4, a percentage reported as inhibition, at one concentration (the size of the read-out at that concentration, not a potency): 97.3%
Compound 4: the middle estimate sits 2.3 percentage points below what was measured; the range from low to high includes it.
By their numbers in this assay, from the lowest: compound 1; then compounds 2, 3 and 4 (each within the scatter of the next).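

In this assay, 2-fluorophenyl in place of 4-fluorophenyl gives a number 2 percentage points higher from compound 3 to compound 4 (within the scatter), so this change on the carbonyl carbon does not bring the same step on every core: the same change on two cores in this assay, a number 73 percentage points higher (beyond the scatter) from compound 1 to compound 2 and a number 2 percentage points higher (within the scatter) from compound 3 to compound 4, 71 percentage points apart, beyond the scatter of two such steps. Amino in place of ethoxy gives a number 7.5 percentage points higher from compound 2 to compound 4 (within the scatter), so its step also depends on the core, and the two changes do not add up: the same change on two cores in this assay, a number 78.5 percentage points higher (beyond the scatter) from compound 1 to compound 3 and a number 7.5 percentage points higher (within the scatter) from compound 2 to compound 4, 71 percentage points apart, beyond the scatter of two such steps.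

Compounds 2, 3 and 4 cannot be ranked from this single concentration. As far as these compounds go, how a methylamino group or a carboxylic acid would fare in place of the amino group remains open.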